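Trifluoromethoxy to hydroxy on a methyl-benzimidazole terphenyl

This account rests on a few compounds, and the source may have more. Where it says the series, first, only, none or still open, it means among the compounds named here.

Measured compounds:
compound 1 `Oc1cccc2[nH]c(-c3ccc(-c4ccc(-c5ccc(OC(F)(F)F)cc5)cc4)cc3)nc12` gives 2210 nM in a functional assay on MCF7 cells (Homo sapiens) for inhibition, read by sulforhodamine B assay; a lower number here means a stronger inhibitor of growth, a higher number a weaker inhibitor of growth
compound 2 `Oc1ccc(-c2ccc(-c3ccc(-c4nc5c(O)cccc5[nH]4)cc3)cc2)cc1` gives 190 nM in this assay
compound 3 `Cc1ccc2[nH]c(-c3ccc(-c4ccc(-c5ccc(OC(F)(F)F)cc5)cc4)cc3)nc2c1` gives 31000 nM in this assay

Compound 4 `Cc1ccc2[nH]c(-c3ccc(-c4ccc(-c5ccc(O)cc5)cc4)cc3)nc2c1` has not yet been measured in this assay. It differs from compound 3 by hydrogen in place of trifluoromethyl on an oxygen on an aromatic ring. The same change was already made once, from compound 1 to compound 2, where it is described as hydrogen in place of trifluoromethyl on an oxygen on an aromatic ring and gave a 12-fold lower number from compound 1 to compound 2 (1.07 log units; beyond the scatter). The two cores differ as 5-methyl-1H-benzimidazol-2-yl in place of 4-hydroxy-1H-benzimidazol-2-yl on an aromatic carbon, a change that alone gave a 14-fold higher number from compound 1 to compound 3 (1.15 log units; beyond the scatter). Since the place of the change is the same in both pairs, the step from compound 3 to compound 4 is expected to be about as large as the earlier one, giving an estimated 10-fold lower number from compound 3 to compound 4 (1.01 log units; beyond the scatter). Going by the values given here, compound 4 is therefore expected to reach about 3000 nM, with a range from 800 nM to 12000 nM allowed for the single precedent.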

Compound 4, concentration for 50% growth inhibition: 12100 nM
Compound 4: middle estimate off by 4.0-fold (0.61 log units), on the low side; measured number above the stated range.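

In this assay the change from trifluoromethoxy to hydroxy again lowered the number on the second core, giving a 2.6-fold lower number from compound 3 to compound 4 (0.41 log units; beyond the scatter), so the direction of the step carried over. Its size did not carry over, and the change cannot be treated as worth a fixed amount across these two cores: the same change on two cores in this assay, a 12-fold lower number (1.07 log units; beyond the scatter) from compound 1 to compound 2 and a 2.6-fold lower number (0.41 log units; beyond the scatter) from compound 3 to compound 4, 4.5-fold (0.66 log units) apart, beyond the scatter of two such steps

Two pairs give no rule for any further core, and they do not show which part of the difference between the cores sets the size of the step. The compounds shown leave open whether a methoxy group or an amine in place of the hydroxy would behave alike on both cores. They also leave open how the step would run on a core bearing a carboxylic acid in place of the methyl.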